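Triazolothiadiazine aryl ketones: fluoro to bromo swap

The source may report more compounds than this note shows. Statements on the series, on what has been measured and on what is new or still open speak of the compounds shown alone.

Measured so far:
compound 1 `COc1cc(-c2nnc3n2NC(c2ccco2)C(C(=O)c2ccc(F)cc2)S3)cc(OC)c1OC`: 53700 nM
compound 2 `COc1cc(-c2nnc3n2NC(c2cccs2)C(C(=O)c2ccc(F)cc2)S3)cc(OC)c1OC`: 45000 nM
compound 3 `COc1ccc(C(=O)C2Sc3nnc(-c4cc(OC)c(OC)c(OC)c4)n3NC2c2cccs2)cc1`: > 100000 nM

In a functional assay on A549 cells (Homo sapiens) for cytotoxicity, read by MTT assay, with a stated time of 48 h (a higher number here means a weaker inhibitor, a lower number a stronger inhibitor), compound 1 gives 53700 nM. Among the compounds with values here, only two plain numbers exist in this assay; compound 2 sits a 1.2-fold lower number from compound 1 to compound 2 (0.08 log units; within the scatter), so the two cannot be ordered. Compound 3 gives > 100000 nM, a limit of the assay and not a number. The step of an at least 2.2-fold higher number from compound 2 to compound 3 (0.34 log units; beyond the scatter) is the only one beyond the scatter here.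

Compound 4 `COc1cc(-c2nnc3n2NC(c2ccco2)C(C(=O)c2cccc(Br)c2)S3)cc(OC)c1OC` differs from compound 1 by 3-bromophenyl in place of 4-fluorophenyl on a carbonyl carbon. Within the data shown here, no measured step changes the same part of the shared core in the same way: the step from compound 2 to compound 3 touches the same aryl ketone, but with a methoxy in place of fluoro, and it reached a limit. That step is taken only as a sign that this aryl group can shift the number by a modest amount, without telling the direction for a bromo at another position.

Compound 4 is therefore expected to give 60000 nM, with a range from 25000 nM to 100000 nM. The estimated step of a 1.1-fold higher number from compound 1 to compound 4 (0.05 log units; within the scatter) is not expected to clear the scatter.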

Compound 4, half-maximal inhibitory concentration: 36900 nM
Estimate against measurement, compound 4: 1.6-fold (0.21 log units) above; the range from low to high includes it.
By their numbers in this assay, from the lowest: compounds 4, 2 and 1 (each within the scatter of the next). At a limit, above all of these: compound 3.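

In this assay, 3-bromophenyl in place of 4-fluorophenyl on the carbonyl carbon gives a 1.5-fold lower number from compound 1 to compound 4 (0.16 log units; within the scatter), so this position tolerates a change of both the halogen and its place on the ring without a step beyond the scatter. Within the data shown here, this is the first step at this position that ends in two plain numbers, and it is also the first there on a compound carrying furan-2-yl. The earlier change at this position, methoxy in place of fluoro, took compound 3 to a limit of the assay and not a number: the limit of > 100000 nM in this assay, at which 1 of the 4 values shown sits.

The compounds shown do not separate the identity of the halogen from its place on the ring. Going by these compounds, how a 4-bromophenyl group, or an amine or a carboxylic acid on this aryl ring, would read in this assay remains open.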